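Restoring the amine hydrogen: compound 3 to compound 4

The source may hold more compounds than are shown below. What is called first, only, known or untested is meant among the compounds shown, and "the series" means these compounds.

Measured so far in an ADME assay on microsomes from liver (Homo sapiens) for metabolic stability, read by LC-MS, with a stated time of 30 min, tested at 1 uM; on this read-out higher numbers stand for a more stable compound and lower numbers for a less stable compound
- compound 1 `CC(C)(C)NCc1cc(Cl)cc(Nc2nc3ccccc3n2Cc2ccc(C(F)(F)F)cc2)c1O` gives 81%
- compound 2 `CCNCc1cc(C)cc(Nc2nc3ccccc3n2Cc2ccc(C(F)(F)F)cc2)c1O` gives 98%
- compound 3 `CCN(CC)Cc1cc(C)cc(Nc2nc3ccccc3n2Cc2ccc(C(F)(F)F)cc2)c1O` gives 36%

Of the three numbers, the lowest belongs to compound 3 (at 36%), and both other compounds stand above it beyond the scatter. Still unmeasured is compound 4 `Cc1cc(CNC(C)(C)C)c(O)c(Nc2nc3ccccc3n2Cc2ccc(C(F)(F)F)cc2)c1`, which differs from compound 3 by (tert-butyl)amino in place of diethylamino on a saturated chain carbon bound to an aromatic carbon and thus reads (diethylamino)methyl to ((tert-butyl)amino)methyl.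

Among the measured compounds shown here, the one measured step that bears on this is a number 62 percentage points lower from compound 2 to compound 3 (beyond the scatter) with ethyl in place of hydrogen on an amine nitrogen. Compound 4 regains a hydrogen on that nitrogen, so a large change upward is expected, the reverse direction of that step. Compound 1 supports this expectation, since it already carries (tert-butyl)amino and gives 81% in this assay even though it has chloro where compound 4 has methyl. For the measured compounds named here, no compound among the three goes against this reading, but three compounds are a thin basis. The expected change is a number 40 percentage points higher from compound 3 to compound 4 (beyond the scatter) and would lie beyond the scatter. The estimated value for compound 4 is 76% (expected range 56% to 93%).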

Compound 4, percent of the compound remaining: 99%
Beside the measured number, compound 4's estimate is 23 percentage points below it, outside the stated range (above it).
By their numbers in this assay, from the lowest: compound 3; then compound 1; then compounds 2 and 4 (each within the scatter of the next).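

In this assay, (tert-butyl)amino in place of diethylamino on a saturated chain carbon bound to an aromatic carbon gives a number 63 percentage points higher from compound 3 to compound 4 (beyond the scatter) with the same atoms joined differently, so the number depends on how those atoms are arranged and not only on which atoms are present. Tert-butyl in place of ethyl on an amine nitrogen gives a number 1 percentage points higher from compound 2 to compound 4 (within the scatter) and so does not separate these two groups on this read-out. Methyl in place of chloro on an aromatic carbon gives a number 18 percentage points higher from compound 1 to compound 4 (beyond the scatter) and so shows, with the amine held constant, that this aromatic group also moves the number.

Open, on these data alone, is whether cyclopropyl on the amine nitrogen, or methoxy in place of methyl on the aromatic carbon, would keep the number of compound 4. Nothing shown gives a reason for any of these steps.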